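Bromo to Chloro on a Second Core: Expecting Compound 4

The source may hold more compounds than are shown below. What is called first, only, known or untested is meant among the compounds shown, and "the series" means these compounds.

Of the compounds shown here, three have been measured in a functional assay on cells (Cancer cell lines, Homo sapiens) for cytotoxicity, read by sulforhodamine B assay, with a stated time of 48 h; on this read-out higher numbers stand for weaker inhibition of growth and lower numbers for stronger inhibition of growth. Compound 1 `COc1ccc(C2=NN(C3=NC(=O)/C(=C4\C(=O)Nc5ccc(Br)cc54)S3)C(c3ccc(Cl)cc3)C2)cc1` gives 140 nM in this assay. Compound 2 `COc1ccc(C2=NN(C3=NC(=O)/C(=C4\C(=O)Nc5ccc(Cl)cc54)S3)C(c3ccc(Cl)cc3)C2)cc1` differs from compound 1 by chloro in place of bromo on an aromatic carbon, and in this assay compound 2 gives 200 nM. The step is a 1.4-fold higher number from compound 1 to compound 2 (0.15 log units; within the scatter). Compound 3 `CN(C)c1ccc(C2CC(c3ccccc3)=NN2C2=NC(=O)/C(=C3\C(=O)Nc4ccc(Br)cc43)S2)cc1` is built on another core; the difference between the core of compound 1 and the core of compound 3 is not broken down here. In this assay compound 3 gives 200 nM, level with compound 2 at the digits recorded and within the scatter of compound 1.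

Compound 4 `CN(C)c1ccc(C2CC(c3ccccc3)=NN2C2=NC(=O)/C(=C3\C(=O)Nc4ccc(Cl)cc43)S2)cc1` has not yet been measured. It differs from compound 3 by chloro in place of bromo on an aromatic carbon. This is the same change as the one from compound 1 to compound 2, made at a place described in the same words, and it occurs twice among the compounds shown. Because the earlier instance gave a 1.4-fold higher number from compound 1 to compound 2 (0.15 log units; within the scatter), a step within the scatter, the new instance is expected to move compound 4 only slightly, if at all, from where compound 3 stands. The step this implies, a 1.4-fold higher number from compound 3 to compound 4 (0.13 log units; within the scatter), is expected to mirror that earlier one, and rests on that single instance alone. Compound 4 is therefore estimated at 270 nM, with a likely range from 130 nM to 560 nM.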

Compound 4, concentration for 50% growth inhibition: 190 nM
For compound 4 the middle estimate is 1.4-fold (0.15 log units) above the measured one; low and high end bracket the measured number.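

Carried over to the core of compound 3, the exchange of bromo for chloro on an aromatic carbon gave a 1.1-fold lower number from compound 3 to compound 4 (0.02 log units; within the scatter) in this assay, so on this core too the change made no difference that stands clear of the usual scatter of the measurement. Set side by side, the two instances of the change agree, and on these two cores the outcome carries over from one to the other: the same change on two cores in this assay, a 1.4-fold higher number (0.15 log units; within the scatter) from compound 1 to compound 2 and a 1.1-fold lower number (0.02 log units; within the scatter) from compound 3 to compound 4, 1.5-fold (0.18 log units) apart, within the scatter of two such steps This shows only that, on two pairs of compounds in a single assay, bromo and chloro at this place can stand in for each other without a step beyond the scatter; it does not show that the same would hold on any further core or at any other place on the molecule, and it gives no reason for the agreement.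

The compounds shown carry only bromo or chloro at this place, so what hydrogen, fluoro, an amine or a carboxylic acid would do there remains open. Also open is how each of the differences between the core of compound 1 and the core of compound 3 bears on the numbers, since no pair shown separates them one at a time.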